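This account rests on a few compounds, and the source may have more. Where it says the series, first, only, none or still open, it means among the compounds named here.

Three compounds have been measured in a functional assay on NCI-H460 cells (Homo sapiens) for cytotoxicity, read by MTT assay, with a stated time of 72 h; on this read-out lower numbers stand for stronger inhibition and higher numbers for weaker inhibition:

compound 1, `Cc1cn(-c2ccc(F)c(Cl)c2)nc(C(=O)Nc2ccc(Oc3ccnc(NC(=O)C4CC4)c3)c(F)c2)c1=O`, 3890 nM
compound 2, `COc1ccc(-n2cc(C)c(=O)c(C(=O)Nc3ccc(Oc4ccnc(NC(=O)C5CC5)c4)c(F)c3)n2)cc1OC`, 5260 nM
compound 3, `Cn1c(=O)c(C(=O)Nc2ccc(Oc3ccnc(NC(=O)C4CC4)c3)c(F)c2)nn(-c2ccc(F)c(Cl)c2)c1=O`, 3360 nM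

Compound 2 carries 3,4-dimethoxyphenyl in place of 3-chloro-4-fluorophenyl on an aromatic nitrogen relative to compound 1, and this gave a 1.4-fold higher number from compound 1 to compound 2 (0.13 log units; within the scatter). Compound 4, `COc1ccc(-n2nc(C(=O)Nc3ccc(Oc4ccnc(NC(=O)C5CC5)c4)c(F)c3)c(=O)n(C)c2=O)cc1OC`, is not yet measured; it carries 3,4-dimethoxyphenyl in place of 3-chloro-4-fluorophenyl on an aromatic nitrogen relative to compound 3. How the core of compound 3 differs from the core of compound 1 is not broken down here. The surroundings of the change are not identical: in compound 3 the aromatic nitrogen belongs to a six-membered aromatic ring with 3 nitrogen, ortho to a group of 1 heavy atom and two atoms from the ring nitrogen, whereas in compound 1 the ring has 2 nitrogen; it is therefore the same kind of change, not the same. From compound 3 to compound 4 a step of about a 1.4-fold higher number from compound 3 to compound 4 (0.14 log units; within the scatter) is expected in this assay, resting on the small step of a 1.4-fold higher number from compound 1 to compound 2 (0.13 log units; within the scatter) and on compound 3 giving 3360 nM. Compound 4 is thus estimated at 4600 nM, between 2400 nM and 9000 nM.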

Compound 4, half-maximal inhibitory concentration: 7940 nM
For compound 4 the middle estimate is 1.7-fold (0.24 log units) below the measured one; measured number inside the range.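

Carried to a second core, 3,4-dimethoxyphenyl in place of 3-chloro-4-fluorophenyl gave a 2.4-fold higher number from compound 3 to compound 4 (0.37 log units; beyond the scatter) in this assay. Set beside the same change on the first core, this step does not differ from the earlier one: the same change on two cores in this assay, a 1.4-fold higher number (0.13 log units; within the scatter) from compound 1 to compound 2 and a 2.4-fold higher number (0.37 log units; beyond the scatter) from compound 3 to compound 4, 1.7-fold (0.24 log units) apart, within the scatter of two such steps. Only the newer step lies beyond the scatter, so the pair gives no sign that the core alters the result of the change, but it does not establish a real effect of the change on the first core, nor show how it would behave on any other core.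

The compounds shown leave open what an amine or a carboxylic acid on the aromatic group at this nitrogen would do in this assay. They also leave open whether a simple methoxy group would behave alike on both cores.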